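Anilino variation on a shared core: propyl to dimethyl

The source may report more compounds than this note shows. Statements on the series, on what has been measured and on what is new or still open speak of the compounds shown alone.

The series shares one core and differs only in the aryl group on the amine nitrogen. Compound 1 `CCCc1ccc(NC2=CC(=O)c3nc4n(c3C2=O)[C@H]2OC[C@@H](O)[C@H]2OC4)cc1` carries a 4-propylphenyl there; in a functional assay on MGC-803 cells (Homo sapiens) for inhibition, read by sulforhodamine B assay (a higher number here means a weaker inhibitor, a lower number a stronger inhibitor), compound 1 gives 1560 nM. Compound 2 `O=C1C(Nc2ccc(C(F)(F)F)cc2)=CC(=O)c2c1nc1n2[C@H]2OC[C@@H](O)[C@H]2OC1` gives 1860 nM, and compound 3 `COc1ccc(NC2=CC(=O)c3c(nc4n3[C@H]3OC[C@@H](O)[C@H]3OC4)C2=O)cc1` gives 2150 nM. Compound 1 thus holds the lowest of the three numbers, but its gaps to compound 2 and compound 3 are within the scatter, so no order among them can be claimed. Within the data shown here, the one measured step, a 1.2-fold higher number from compound 2 to compound 3 (0.06 log units; within the scatter), likewise stays within the scatter.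

Compound 4 `Cc1ccc(NC2=CC(=O)c3nc4n(c3C2=O)[C@H]2OC[C@@H](O)[C@H]2OC4)cc1C` differs from compound 1 in this way: 3,4-dimethylphenyl in place of 4-propylphenyl on an amine nitrogen. Among the measured compounds shown here, no measured step swaps one alkyl pattern for another on that aryl ring, so only the general picture applies: three different aryl substituents gave numbers within the scatter of one another. On that basis compound 4 is expected to show a 1.1-fold higher number from compound 1 to compound 4 (0.04 log units; within the scatter), a change not beyond the scatter. The estimate for compound 4 is 1700 nM, with a range from 800 nM to 3600 nM.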

Compound 4, half-maximal inhibitory concentration: 860 nM
Compound 4: middle estimate off by 2.0-fold (0.30 log units), on the high side; low and high end bracket the measured number.
By their numbers in this assay, from the lowest: compounds 4, 1, 2 and 3 (each within the scatter of the next, the first and the last beyond it).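

In this assay, 3,4-dimethylphenyl in place of 4-propylphenyl on the amine nitrogen gives a 1.8-fold lower number from compound 1 to compound 4 (0.26 log units; within the scatter), so this single change cannot be told apart from the scatter of repeated measurements. The result does add something the first three compounds did not show: with compound 4 at 860 nM and compound 3 at 2150 nM, two aryl groups at this position now give values beyond the scatter of each other. No supporting measurement is available to explain this difference.

The compounds shown leave open whether a single methyl, a longer chain such as butyl, or an aryl ring bearing an amine or a carboxylic acid would widen this spread. They also leave open whether any aryl group at this position can move the number beyond the scatter of compound 1.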